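The compounds below may be only part of what the source reports. "The series", "measured", "known", "first", "only" and "open" are said of these compounds alone.

The core of compound 1 `CN(CC[C@H](N)C(=O)O)C[C@H]1O[C@@H](n2cnc3c(N)ncnc32)[C@H](O)[C@@H]1O` is shared across the series; in an assay for inhibition of tRNA (cytosine(38)-C(5))-methyltransferase (Homo sapiens), with a stated time of 5 min, tested at 100 uM (a higher number here means more inhibition at the concentration tested (going by the name of the read-out), a lower number less inhibition), compound 1 gives 30.3%. Compound 2 `Nc1ncnc2c1ncn2[C@@H]1O[C@H](CN(CC[C@H](N)C(=O)O)CC2CCC2)[C@@H](O)[C@H]1O` gives 32% and compound 3 `Nc1ncnc2c1ncn2[C@@H]1O[C@H](CN(CC[C@H](N)C(=O)O)CC2CCCC2)[C@@H](O)[C@H]1O` gives 24.5%. Compound 3 sits together with the other two rather than apart from them: a number 5.8 percentage points lower from compound 1 to compound 3 (within the scatter) and a number 7.5 percentage points lower from compound 2 to compound 3 (within the scatter). Compound 4 `CC#CCN(CC[C@H](N)C(=O)O)C[C@H]1O[C@@H](n2cnc3c(N)ncnc32)[C@H](O)[C@@H]1O` differs from compound 3 by prop-1-yn-1-yl in place of cyclopentyl on a saturated chain carbon bound to an amine nitrogen. Within the data shown here, no measured step brings in a prop-1-yn-1-yl group, so the only guidance comes from the steps at this position, a number 1.7 percentage points higher from compound 1 to compound 2 (within the scatter), a number 5.8 percentage points lower from compound 1 to compound 3 (within the scatter) and a number 7.5 percentage points lower from compound 2 to compound 3 (within the scatter), all within the scatter; accordingly no movement beyond the scatter is expected in this assay, a number 4.5 percentage points higher from compound 3 to compound 4 (within the scatter). Compound 4 is estimated at 29%, with a range from 15% to 43%.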

Compound 4, a percentage reported as inhibition, at one concentration (the size of the read-out at that concentration, not a potency): 61.3%
The estimate for compound 4 lay 32.3 percentage points below the measured number; measured number outside the range, above it.
By their numbers in this assay, from the lowest: compounds 3, 1 and 2 (each within the scatter of the next); then compound 4.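

In this assay the place on a saturated chain carbon bound to an amine nitrogen turns out able to move the read-out, which the hydrogen, cyclobutyl and cyclopentyl compounds did not show: prop-1-yn-1-yl gives a number 36.8 percentage points higher from compound 3 to compound 4 (beyond the scatter) and a number 29.3 percentage points higher from compound 2 to compound 4 (beyond the scatter) and a number 31 percentage points higher from compound 1 to compound 4 (beyond the scatter). Among these compounds, compound 4 is thus the only compound of the four that stands apart from the others. Nothing available accounts for this rise.

Going by these compounds, whether the rise depends on the triple bond stays open: a saturated butyl chain or a but-2-en-1-yl chain at this place would test that. On these data alone, how a longer alkyne chain or a terminal alkyne would read also remains open.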